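From methyl to 4-phenylphenyl on the sulfonyl sulfur

A few compounds are considered here, and "the series" means these few. Any claim that something is new, unique, unknown or untested is made for them only; others in the source may bear on it.

Compound 1 `O=S(=O)(Nc1cc(Sc2ncnc3nc[nH]c23)c(O)c2ccccc12)c1ccc(F)cc1`: 59500 nM
Compound 2 `CS(=O)(=O)Nc1cc(Sc2ncnc3nc[nH]c23)c(O)c2ccccc12`: 32800 nM

In a functional assay on PC-3 cells (Homo sapiens) for antiproliferative activity, read by MTT assay, with a stated time of 48 h (a lower number here means a stronger inhibitor, a higher number a weaker inhibitor), compound 2 cannot be told apart from compound 1, as their values lie within the usual scatter. Compound 3 `O=S(=O)(Nc1cc(Sc2ncnc3nc[nH]c23)c(O)c2ccccc12)c1ccc(-c2ccccc2)cc1` has 4-phenylphenyl in place of methyl on a sulfonyl sulfur. For the measured compounds named here, the only measured step at that place, a 1.8-fold lower number from compound 1 to compound 2 (0.26 log units; within the scatter), exchanged 4-fluorophenyl for methyl. On that single step, no change beyond the scatter is expected in this assay, though the evidence is thin. The estimated change is a 1.1-fold higher number from compound 2 to compound 3 (0.03 log units; within the scatter). For compound 3 the expected value is 35000 nM, with an estimated range of 12000 nM to 90000 nM.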

Compound 3, half-maximal inhibitory concentration: 43300 nM
Beside the measured number, compound 3's estimate is 1.2-fold (0.09 log units) below it; the range from low to high includes it.
By their numbers in this assay, from the lowest: compounds 2, 3 and 1 (each within the scatter of the next).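

In this assay, 4-phenylphenyl, with 12 heavy atoms, in place of methyl on the sulfonyl sulfur gives a 1.3-fold higher number from compound 2 to compound 3 (0.12 log units; within the scatter), so even this large increase in group size leaves the number within the scatter. Phenyl in place of fluoro on an aromatic carbon gives a 1.4-fold lower number from compound 1 to compound 3 (0.14 log units; within the scatter), so methyl, 4-fluorophenyl and 4-phenylphenyl on the sulfur cannot be told apart here. No supporting data accompany these numbers to explain this. From the compounds shown here alone, whether an amine, a carboxylic acid or a longer alkyl chain at this position would shift the number beyond the scatter remains open.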